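From Methyl to Methylsulfanyl in Compound 4

The source may report more compounds than this note shows. Statements on the series, on what has been measured and on what is new or still open speak of the compounds shown alone.

Measured so far in a functional assay on DU-145 cells (Homo sapiens) for inhibition, read by MTT assay, with a stated time of 48 h; on this read-out higher numbers stand for weaker inhibition and lower numbers for stronger inhibition:
compound 1 `CCc1ccc(-c2nc3ccccn3c2Sc2ccccc2)cc1` gives 84500 nM
compound 2 `Cc1ccc(-c2nc3ccccn3c2Sc2ccccc2)cc1` gives 83300 nM
compound 3 `c1ccc(Sc2c(-c3cccc4ccccc34)nc3ccccn23)cc1` gives 60600 nM

Compound 2 stands among three values that all lie within the scatter of one another, so no order can be read from them. Compound 4 `CSc1ccc(-c2nc3ccccn3c2Sc2ccccc2)cc1` differs from compound 2 by a single change: methylsulfanyl in place of methyl on an aromatic carbon (methylsulfanyl in place of methyl on an aromatic carbon, para to a large group). Among the compounds with values here, only one measured step bears on this, and only loosely. It is a 1.0-fold lower number from compound 1 to compound 2 (0.01 log units; within the scatter) and it falls on a saturated chain carbon, not on the aromatic carbon. Within the data shown here, no measured compound carries methylsulfanyl, so the data give no direct guide to this change. With so little evidence, no step beyond the scatter is expected in this assay and no direction is favoured. The estimated step is a 1.1-fold lower number from compound 2 to compound 4 (0.05 log units; within the scatter) and it is expected to stay within the scatter. Compound 4 is expected at 75000 nM with an estimated range from 35000 nM to 150000 nM on this read-out.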

Compound 4, half-maximal inhibitory concentration: 52100 nM
Compound 4: middle estimate off by 1.4-fold (0.16 log units), on the high side, and the stated range covers the measured number.
By their numbers in this assay, from the lowest: compounds 4, 3, 2 and 1 (each within the scatter of the next).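

In this assay, within the data shown here, the first sulfur-bearing group at this place on the aromatic ring gives a 1.6-fold lower number from compound 2 to compound 4 (0.20 log units; within the scatter), and the same comparison against the ethyl compound gives a 1.6-fold lower number from compound 1 to compound 4 (0.21 log units; within the scatter). Methyl, ethyl and methylsulfanyl therefore cannot be told apart on this read-out, so this change, which adds a sulfur atom and a hydrogen-bond acceptor, shows no effect here that stands clear of the scatter. No independent evidence is available to interpret these small steps.

The compounds shown leave open whether any group at this place can move the number beyond the scatter. An amine, a carboxylic acid or a longer chain in the same spot might behave differently from these three groups, and nothing here predicts the size or direction of such a step.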